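Moving the fluorine and methyl groups on compound 3

The compounds below may be only part of what the source reports. "The series", "measured", "known", "first", "only" and "open" are said of these compounds alone.

Compound 1 `O=C(Nc1cn2cc(I)ccc2n1)C(F)(F)F`: 20.8%
Compound 2 `O=C(c1ccc(C(F)(F)F)c(F)c1)c1ccc2nc(NC(=O)C(F)(F)F)cn2c1`: 38.4%
Compound 3 `Cc1ccc(F)c(C(=O)c2ccc3nc(NC(=O)C(F)(F)F)cn3c2)c1`: 61.5%

In a functional assay on U-251 cells (Homo sapiens) for inhibition, read by sulforhodamine B assay, with a stated time of 48 h, tested at 50 uM (a higher number here means more inhibition of growth at the concentration tested, a lower number less inhibition of growth), compound 3 stands highest of the three at 61.5%, beyond the scatter from both of the others. Compound 4 `Cc1ccc(C(=O)c2ccc3nc(NC(=O)C(F)(F)F)cn3c2)cc1F` keeps the same atoms, with 3-fluoro-4-methylphenyl in place of 2-fluoro-5-methylphenyl on a carbonyl carbon. For the measured compounds named here, no measured pair isolates a single change, so any forecast is loose. Compound 2 carries a different group on that carbonyl carbon and reads 38.4%, so a moderate fall is expected rather than a rise. The expected move, a number 11.5 percentage points lower from compound 3 to compound 4 (beyond the scatter), is estimated to lie slightly beyond the scatter. For compound 4 the estimated value is 50%, with an expected range from 32% to 68%.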

Compound 4, percent growth inhibition at one concentration: 37.9%
Compound 4: the middle estimate sits 12.1 percentage points above what was measured; measured number inside the range.
By their numbers in this assay, from the lowest: compound 1; then compounds 4 and 2 (each within the scatter of the next); then compound 3.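

In this assay, the arrangement of the same atoms proves enough to matter: 3-fluoro-4-methylphenyl in place of 2-fluoro-5-methylphenyl on a carbonyl carbon gives a number 23.6 percentage points lower from compound 3 to compound 4 (beyond the scatter). With 3-fluoro-4-methylphenyl kept in view, methyl in place of trifluoromethyl on an aromatic carbon gives a number 0.5 percentage points lower from compound 2 to compound 4 (within the scatter), so these two groups cannot be told apart in this read-out. Nothing available explains either step.

From the compounds shown here alone, whether a methoxy group or an amine in place of the methyl of compound 3 would keep its reading remains open. So does whether fluorine itself is needed on that ring.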